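A hydroxy group on the sulfonamide chain of compound 3

The source may report more compounds than this note shows. Statements on the series, on what has been measured and on what is new or still open speak of the compounds shown alone.

Compound 1 `CC[C@@H]1C(=O)N(C)c2cnc(Nc3ccc(S(=O)(=O)NC4CCCC4)cc3)nc2N1C1CCCC1` gives 389 nM in a functional assay on Huh-7 cells (Homo sapiens) for antiproliferative activity, read by CCK-8 assay, with a stated time of 72 h; a higher number here means a weaker inhibitor of growth, a lower number a stronger inhibitor of growth.
Compound 2 `CC[C@@H]1C(=O)N(C)c2cnc(Nc3ccc(S(N)(=O)=O)cc3)nc2N1C1CCCC1` gives 1300 nM in this assay.
Compound 3 `CCCCNS(=O)(=O)c1ccc(Nc2ncc3c(n2)N(C2CCCC2)[C@H](CC)C(=O)N3C)cc1` gives 225 nM in this assay.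

Compound 3 carries the lowest of the three numbers in this assay, though its separation from compound 1 is only a 1.7-fold lower number from compound 1 to compound 3 (0.24 log units; within the scatter), within the scatter, while from compound 2 it stands at a 5.8-fold lower number from compound 2 to compound 3 (0.76 log units; beyond the scatter), beyond it. Compound 4 `CC[C@@H]1C(=O)N(C)c2cnc(Nc3ccc(S(=O)(=O)NCCCO)cc3)nc2N1C1CCCC1` differs from compound 3 in one place: hydroxy in place of methyl on a saturated chain carbon, three bonds along the chain from a sulfonamide nitrogen. Every measured step changes the group on the sulfonamide nitrogen. Cyclopentyl and butyl give numbers within the scatter of each other, whereas hydrogen in place of cyclopentyl gives a 3.3-fold higher number from compound 1 to compound 2 (0.52 log units; beyond the scatter). Going by the values given here, in compound 4 the nitrogen keeps a 3-hydroxypropyl chain, so a substituent remains, but no measured compound carries a hydroxy there, and the step from compound 3 is expected to be at most modest, more likely toward a higher number. Compound 4 is therefore estimated at 420 nM, between 150 nM and 1200 nM, an expected step of a 1.9-fold higher number from compound 3 to compound 4 (0.27 log units; within the scatter).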

Compound 4, concentration for 50% growth inhibition: 262 nM
Compound 4: the middle estimate sits 1.6-fold (0.20 log units) above what was measured; low and high end bracket the measured number.
By their numbers in this assay, from the lowest: compounds 3, 4 and 1 (each within the scatter of the next); then compound 2.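

Hydroxy in place of methyl on a saturated chain carbon, three bonds along the chain from a sulfonamide nitrogen, leaves the number in this assay within the scatter (a 1.2-fold higher number from compound 3 to compound 4 (0.07 log units; within the scatter)), so in this pair the change does not move the result measurably. The 3-hydroxypropyl chain also stands within the scatter of cyclopentyl (a 1.5-fold lower number from compound 1 to compound 4 (0.17 log units; within the scatter)) but beyond it from hydrogen (a 5.0-fold lower number from compound 2 to compound 4 (0.70 log units; beyond the scatter)), which places compound 4 with compound 1 and compound 3, while compound 2, with no substituent on the sulfonamide nitrogen, stands apart. Nothing measured here accounts for this outcome.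

The compounds shown leave open whether an amine or a carboxylic acid in the same place would keep the number in this range. They also leave open whether a longer chain carrying the hydroxy would do so.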